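A few compounds are considered here, and "the series" means these few. Any claim that something is new, unique, unknown or untested is made for them only; others in the source may bear on it.

In an assay on mitochondria (strain BALB/c) for inhibition of glycerol-3-phosphate acyltransferase 1, mitochondrial (Mus musculus), read by scintillation counting, with a stated time of 10 min (on this read-out higher numbers stand for weaker inhibition and lower numbers for stronger inhibition), compound 1 `CCCCCCCCS(=O)(=O)Nc1cc(-c2ccccc2O)ccc1C(=O)O` gives 63100 nM. Compound 2 `CCCCCCCCS(=O)(=O)Nc1cc(-c2ccc(O)cc2)ccc1C(=O)O`, in which (4-hydroxyphenyl in place of 2-hydroxyphenyl on an aromatic carbon), gives 64800 nM in this assay, so that a 1.0-fold higher number from compound 1 to compound 2 (0.01 log units; within the scatter). Compound 3 `CCCCCCCCS(=O)(=O)Nc1ccc(-c2ccccc2O)cc1C(=O)O` gives 61700 nM in this assay; how its core differs from the core of compound 1 is not broken down here. Compound 4 `CCCCCCCCS(=O)(=O)Nc1ccc(-c2ccc(O)cc2)cc1C(=O)O` has not yet been measured; in it (4-hydroxyphenyl in place of 2-hydroxyphenyl on an aromatic carbon). This is the same kind of change as that made between compound 1 and compound 2, though not the same: in compound 3 the group sits meta to a carboxy group and para to a large group, whereas in compound 1 it sits meta to a large group and para to a carboxy group. Because a 1.0-fold higher number from compound 1 to compound 2 (0.01 log units; within the scatter), a similarly small step is expected here, a 1.0-fold higher number from compound 3 to compound 4 (0.01 log units; within the scatter). Compound 4 is accordingly estimated at 63000 nM.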

Compound 4, half-maximal inhibitory concentration: 47300 nM
Compound 4: middle estimate off by 1.3-fold (0.12 log units), on the high side; low and high end bracket the measured number.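

With 4-hydroxyphenyl in place of 2-hydroxyphenyl on the core of compound 3, this assay gives a 1.3-fold lower number from compound 3 to compound 4 (0.12 log units; within the scatter), and the step on this core can be set beside the earlier one on the core of compound 1: the same change on two cores in this assay, a 1.0-fold higher number (0.01 log units; within the scatter) from compound 1 to compound 2 and a 1.3-fold lower number (0.12 log units; within the scatter) from compound 3 to compound 4, 1.3-fold (0.13 log units) apart, within the scatter of two such steps. The change therefore carries from one of these two cores to the other without any difference that can be told from the scatter. Within the data shown here, neither step stands beyond the scatter, however, so this shows only that the change does little on both cores and says nothing of any other core. From the compounds shown here alone, whether an amine or a carboxylic acid in place of the hydroxyl would behave the same way on both cores remains open. So does the effect of a longer chain.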